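Indole piperidine series: benzylamine variants at the terminal nitrogen

A few compounds are considered here, and "the series" means these few. Any claim that something is new, unique, unknown or untested is made for them only; others in the source may bear on it.

Measured compounds:
- compound 1 `C[C@@H](NCC1CCN(CCCc2c[nH]c3ccc(-n4cnnc4)cc23)CC1)c1ccccc1`: 1.4 nM
- compound 2 `CN(Cc1ccccc1)CC1CCN(CCCc2c[nH]c3ccc(-n4cnnc4)cc23)CC1`: 0.9 nM
- compound 3 `C[C@H](NCC1CCN(CCCc2c[nH]c3ccc(-n4cnnc4)cc23)CC1)c1ccccc1`: 4.4 nM

In an assay on CHO cells for displacement of a labelled ligand from 5-hydroxytryptamine receptor 1D (Homo sapiens) (on this read-out lower numbers stand for stronger inhibition and higher numbers for weaker inhibition), compound 3 gives the highest number of the three. The step of a 3.1-fold higher number from compound 1 to compound 3 (0.50 log units; beyond the scatter) rests on (the fact that compounds 1 and 3 differ only in the configuration as drawn); the step of a 4.9-fold higher number from compound 2 to compound 3 (0.69 log units; beyond the scatter) shows the branched (1-phenylethyl)amino in the less favourable configuration sitting behind the benzyl(methyl)amino analogue.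

Compound 4 `CC(=O)Nc1ccc(CNCC2CCN(CCCc3c[nH]c4ccc(-n5cnnc5)cc34)CC2)cc1` carries the change (4-acetamidobenzyl in place of 1-phenylethyl on an amine nitrogen), so the stereocentre is gone and the substituent returns to a benzyl-type amine, now bearing an acetamido group.

Both steps above bear on this. Since compound 2 gives 0.9 nM with an unbranched benzyl, a move back toward that level is expected, tempered by the new polar group. Compound 4 is expected at 2 nM (range 0.5 nM to 8 nM), a step of a 2.2-fold lower number from compound 3 to compound 4 (0.34 log units; beyond the scatter) estimated in this assay.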

Compound 4, half-maximal inhibitory concentration: 4.2 nM
The estimate for compound 4 lay 2.1-fold (0.32 log units) below the measured number; the range from low to high includes it.
By their numbers in this assay, from the lowest: compounds 2 and 1 (each within the scatter of the next); then compounds 4 and 3 (each within the scatter of the next).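

In this assay, 4-acetamidobenzyl on the amine nitrogen removes the stereocentre and still matches the less favourable 1-phenylethyl configuration (a 1.0-fold lower number from compound 3 to compound 4 (0.02 log units; within the scatter)). Against the other configuration and the benzyl(methyl)amino analogue, the steps are beyond the scatter (first a 3.0-fold higher number from compound 1 to compound 4 (0.48 log units; beyond the scatter), then a 4.7-fold higher number from compound 2 to compound 4 (0.67 log units; beyond the scatter)), so compound 4 groups with compound 3. The data shown give no cause for these steps.

Going by these compounds, what the acetamido group contributes on its own remains open; a plain benzylamino or a 4-aminobenzyl group on this nitrogen would bear on that.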